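The compounds below may be only part of what the source reports. "The series", "measured", "known", "first", "only" and "open" are said of these compounds alone.

Compound 2 `Oc1ccc(-c2cc(-c3cccc(OC(F)(F)F)c3)cc(-c3cccc(O)c3)n2)cc1` gives 1730 nM in a functional assay on HCT-15 cells (Homo sapiens) for inhibition (a higher number here means a weaker inhibitor, a lower number a stronger inhibitor), the only number shown for the series. Compound 1 `Oc1ccc(-c2cc(-c3cccc(F)c3)cc(-c3ccc(O)cc3)n2)cc1` gives > 50000 nM in this assay, which is a limit and not a number. Compound 1 thus sits at the limit of > 50000 nM in this assay, at which 1 of the 2 values shown sits. Compound 3 `Oc1ccc(-c2cc(-c3cccc(OC(F)(F)F)c3)cc(-c3ccc(O)cc3)n2)cc1` differs from compound 2 by 4-hydroxyphenyl in place of 3-hydroxyphenyl on an aromatic carbon. Going by the values given here, no step between measured compounds covers this change. Compound 1, itself bearing 4-hydroxyphenyl rather than 3-hydroxyphenyl, stands at the limit. For compound 3 a step toward weaker inhibition beyond the scatter is therefore expected, a 3.5-fold higher number from compound 2 to compound 3 (0.54 log units; beyond the scatter). Compound 3 is estimated at 6000 nM in this assay, within 1200 nM to 50000 nM.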

Compound 3, half-maximal inhibitory concentration: > 50000 nM
Compound 3: only a limit was reported (the forecaster's own chance of this, stated with the estimate: 30%); middle value at least 8.3-fold (0.92 log units) from the limit.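

With trifluoromethoxy held constant, 4-hydroxyphenyl in place of 3-hydroxyphenyl next to the ring nitrogen gives an at least 28-fold higher number from compound 2 to compound 3 (1.46 log units; beyond the scatter) in this assay, so this position separates two groups made of the same atoms. The value of compound 3 is a limit, and the step is a lower bound only. In this pair only the compound bearing 3-hydroxyphenyl gives a number, and the step between the two limits cannot be read: the limit of > 50000 nM in this assay, at which 2 of the 3 values shown sit.

Going by these compounds, whether the hydroxyl of 3-hydroxyphenyl is itself required remains open; 3-methoxyphenyl or 3-aminophenyl in this place would bear on that. Also open, on these data alone, is how fluoro in place of trifluoromethoxy behaves with 3-hydroxyphenyl retained.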